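The source may report more compounds than this note shows. Statements on the series, on what has been measured and on what is new or still open speak of the compounds shown alone.

Measured so far in a functional assay on PC-3 cells (Homo sapiens) for cytotoxicity; on this read-out higher numbers stand for weaker inhibition and lower numbers for stronger inhibition:
Compound 1 `Oc1cccc(/C=N/n2cnnc2)c1O`: > 30000 nM
Compound 2 `Oc1cccc(/C=N/n2cnnc2)c1`: > 30000 nM

Compound 1 has no exact number, only a limit of > 30000 nM. Compound 2 is likewise reported only as a limit, at > 30000 nM. Both compounds therefore sit at the limit of > 30000 nM in this assay, at which 2 of the 2 values shown sit.

Compound 3 `CCOc1cccc(/C=N/n2cnnc2)c1O` has not yet been measured. It differs from compound 1 by ethyl in place of hydrogen on an oxygen on an aromatic ring, which turns a hydroxy into an ethoxy on the shared core. Within the data shown here, only one measured step bears on this change, and only loosely: a step that the two limits leave unreadable from compound 1 to compound 2. That step removes the other hydroxy of compound 1, not the one that becomes ethoxy, and it offers no size to carry over. Compound 1 remains the only reference point, and its > 30000 nM is a limit, so no step beyond the scatter is expected in this assay. The estimated step is a step that the limit leaves unreadable from compound 1 to compound 3. Compound 3 is expected at about 35000 nM, within an estimated range of 12000 nM to 100000 nM, and may well be reported only as a limit.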

Compound 3, half-maximal inhibitory concentration: > 30000 nM
Compound 3 was reported as a limit (the forecaster's own chance of this, stated with the estimate: 75%); the middle value lies beyond the limit too.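

In this assay, compound 1 and compound 3 are both reported only as limits, and no new step can be read from the pair: the limit of > 30000 nM in this assay, at which 3 of the 3 values shown sit. The compounds shown leave open whether ethoxy in place of hydroxy changes this read-out at all, since none of them has an exact value.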